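Compound 3 to compound 4: a new side chain

This account rests on a few compounds, and the source may have more. Where it says the series, first, only, none or still open, it means among the compounds named here.

Of the compounds shown here, three sharing one core have been read in a functional assay on MDA-MB-231 cells (Homo sapiens) for cytotoxicity, read by MTT assay, with a stated time of 72 h; on this read-out lower numbers stand for stronger inhibition and higher numbers for weaker inhibition. Compound 1 `O=C1c2c[n+]([O-])c3ccccc3c2C(=O)c2c1c1ccccc1n2Cc1cn([C@@H]2C[C@H](O)[C@@H](CO)O2)nn1` gives 130 nM, compound 2 `CC1(C)OCC(Cn2cc(Cn3c4c(c5ccccc53)C(=O)c3c[n+]([O-])c5ccccc5c3C4=O)nn2)O1` gives 230 nM, and compound 3 `O=C1c2c[n+]([O-])c3ccccc3c2C(=O)c2c1c1ccccc1n2Cc1cn(CC(O)CO)nn1` gives 1290 nM, the highest number of the three. The next structure, compound 4 `O=C1c2c[n+]([O-])c3ccccc3c2C(=O)c2c1c1ccccc1n2CCCCN1CCNCC1`, carries 3-(piperazin-1-yl)propyl in place of 1-(2,3-dihydroxypropyl)-1H-1,2,3-triazol-4-yl on a saturated chain carbon bound to an aromatic nitrogen. Within the data shown here, no measured step replaces that whole group, so the measured steps offer only a rough guide to how far changes at this end move the number. a 1.8-fold higher number from compound 1 to compound 2 (0.25 log units; within the scatter) stays within the scatter, while a 9.9-fold higher number from compound 1 to compound 3 (1.00 log units; beyond the scatter) and a 5.6-fold higher number from compound 2 to compound 3 (0.75 log units; beyond the scatter) are modest. With compound 3 at 1290 nM, the top of that span, a modest move toward lower numbers is expected, with wide uncertainty. The expected step is a 2.6-fold lower number from compound 3 to compound 4 (0.41 log units; beyond the scatter). The estimate for compound 4 is 500 nM, within a range of 100 nM to 2500 nM.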

Compound 4, half-maximal inhibitory concentration: 3310 nM
For compound 4 the middle estimate is 6.6-fold (0.82 log units) below the measured one, and the stated range ends below it.
By their numbers in this assay, from the lowest: compounds 1 and 2 (each within the scatter of the next); then compound 3; then compound 4.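

In this assay, the step to 3-(piperazin-1-yl)propyl on a saturated chain carbon bound to an aromatic nitrogen is a 2.6-fold higher number from compound 3 to compound 4 (0.41 log units; beyond the scatter). Compounds 1, 2 and 3 all keep the 1,2,3-triazol-4-yl group and differ only in what it carries, whereas compound 4 is the first shown without that ring, and it has the highest number of the four, so a piperazine-ended chain at this position does not recover the lower numbers of compound 1 and compound 2. No measurement shown accounts for this rise.

This single step changes the ring, the chain and the end group together, so their separate contributions cannot be read from it. Open, as far as these compounds go, is how a morpholine on the same chain, or a piperazine attached through the 1,2,3-triazol-4-yl group, would read in this assay.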